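The source may report more compounds than this note shows. Statements on the series, on what has been measured and on what is new or still open speak of the compounds shown alone.

Compound 1 `CCCCC/C=C/CCCCCCCCCC1(C(=O)OC)CO1` is the more potent of the two measured compounds in a functional assay on the whole organism with Rattus norvegicus as the target, in the glucose tolerance test (a higher number here means that more compound is needed for the effect, a lower number that less compound is needed), where compound 1 requires 10 mg/kg. Compound 2 `CCCCCCCCCCCCCCC1(C(=O)NCCO)CO1` differs from compound 1 in several places. In this assay compound 2 requires 100 mg/kg, a clearly higher figure. Compound 3 `COC(=O)C1(CCCCCCCCCCc2ccccc2)CO1` has not yet been measured; it differs from compound 1 only by benzyl in place of hept-1-en-1-yl on a saturated chain carbon, nine bonds along the chain from a saturated ring carbon. Among the compounds with values here, with no single-change step available as a guide, a step from compound 1 to compound 3 is expected to be small, a 1.5-fold higher number from compound 1 to compound 3 (0.18 log units; within the scatter), within the scatter or a little beyond it in either direction. Compound 3 is therefore estimated at 15 mg/kg, likely between 3 mg/kg and 100 mg/kg.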

Compound 3, minimum effective dose: 10 mg/kg
Compound 3: middle estimate off by 1.5-fold (0.18 log units), on the high side, within the range that was stated.
By their numbers in this assay, from the lowest: compounds 1 and 3 (each within the scatter of the next); then compound 2.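

In this assay, benzyl in place of hept-1-en-1-yl on a saturated chain carbon, nine bonds along the chain from a saturated ring carbon, gives no change at the digits printed from compound 1 to compound 3 (within the scatter) and so no shift beyond the scatter. This position therefore accepts a six-membered aromatic ring of carbon only in place of an open chain with a double bond, which compound 2, differing from compound 1 in several places, could not show.

From the compounds shown here alone, whether an amine, a carboxylic acid or a longer chain at this place would hold the dose remains open. Nothing available bears on why the two groups match.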